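Swapping the oxazole for a pyrazole on a fused core

The compounds below may be only part of what the source reports. "The series", "measured", "known", "first", "only" and "open" are said of these compounds alone.

Among the compounds with values here, compound 3 `c1cc(-c2ncco2)c2c(c1)C(c1ncc[nH]1)CC2` stands highest of the three compounds measured so far: in a functional assay on CHO cells for agonist activity at Alpha-1A adrenergic receptor (Homo sapiens), read by FLIPR and calcium flux (on this read-out higher numbers stand for larger maximal responses and lower numbers for smaller maximal responses), compound 3 gives 63%. Compound 1 `Cn1ccc(-c2cccc3c2CCC3c2ncc[nH]2)n1` gives 19% in this assay, and compound 2 `Cn1cc(-c2cccc3c2CCC3c2ncc[nH]2)cn1` gives 12%. The steps of a number 44 percentage points higher from compound 1 to compound 3 (beyond the scatter) and a number 51 percentage points higher from compound 2 to compound 3 (beyond the scatter) are both large, whereas the step of a number 7 percentage points lower from compound 1 to compound 2 (within the scatter) is not. Compound 4 `c1cc(-c2cn[nH]c2)c2c(c1)C(c1ncc[nH]1)CC2` differs from compound 3 in one place: 1H-pyrazol-4-yl in place of 1,3-oxazol-2-yl on an aromatic carbon. The two large steps bear on this change, since each replaced a methylated pyrazole by the oxazole and the maximal response rose strongly. Compound 4 goes back to a pyrazole, here the 1H-pyrazol-4-yl with a free ring hydrogen, which closely resembles the group on compound 2. A drop of similar size is expected because compound 2 gives 12% in this assay, though the missing methyl leaves some uncertainty. Compound 4 is therefore expected to give about 25%, with a likely range from 8% to 50%. This estimate means a step of a number 38 percentage points lower from compound 3 to compound 4 (beyond the scatter), expected to lie beyond the scatter.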

Compound 4, largest response reached (Emax), in percent of the reference or control that the assay uses: 84%
The estimate for compound 4 lay 59 percentage points below the measured number; measured number outside the range, above it.
By their numbers in this assay, from the lowest: compounds 2 and 1 (each within the scatter of the next); then compound 3; then compound 4.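

In this assay, taking the methyl off the ring nitrogen of the pyrazole is the decisive change, with a number 72 percentage points higher from compound 2 to compound 4 (beyond the scatter), so a pyrazole on this aromatic carbon does not by itself go with a small maximal response. The free pyrazole also surpasses the oxazole, with a number 21 percentage points higher from compound 3 to compound 4 (beyond the scatter), and the comparison with the other methylated pyrazole gives a number 65 percentage points higher from compound 1 to compound 4 (beyond the scatter), although that step changes the pyrazole's point of attachment as well as removing the methyl. Nothing available here explains these differences in response.

As far as these compounds go, it remains open whether an ethyl group on the same ring nitrogen would bring the response down as the methyl does. From the compounds shown here alone, it is also open whether a 1H-pyrazol-3-yl group, with its ring hydrogen free, would match the 1H-pyrazol-4-yl group.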